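Trading a phenyl for isopropyl on compound 1

The source may report more compounds than this note shows. Statements on the series, on what has been measured and on what is new or still open speak of the compounds shown alone.

Of the compounds shown here, three sharing a pyrazole-carboxamide core have been measured in an assay on isolated protein for inhibition of Group 10 secretory phospholipase A2 (Homo sapiens), with a stated time of 30 min; on this read-out lower numbers stand for stronger inhibition and higher numbers for weaker inhibition. Compound 1 `Cc1sc(-c2ccccc2)cc1-c1cc(C(N)=O)n[nH]1` gives 347 nM, the lowest number of the three. Compound 2 `NC(=O)c1cc(-c2ccccc2Cl)[nH]n1` gives 9330 nM, and compound 3 `Cc1ccccc1-c1cc(C(N)=O)n[nH]1` gives 2750 nM. Among the compounds with values here, the single one-place step among them is a 3.4-fold lower number from compound 2 to compound 3 (0.53 log units; beyond the scatter). Compound 1 stands well apart: compound 3 is its nearest neighbour and compound 2 its furthest, both beyond the scatter.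

Compound 4 `Cc1sc(C(C)C)cc1-c1cc(C(N)=O)n[nH]1` is not yet measured. It differs from compound 1 as follows: isopropyl in place of phenyl on an aromatic carbon. Within the data shown here, no measured step speaks to this change; the only step, from compound 2 to compound 3, concerns a substituent on a phenyl rather than the removal of a phenyl. Among the measured compounds shown here, what can be said is that compound 1, the only one with the phenyl on the five-membered aromatic ring with 1 sulfur, is also the one with the lowest number, so he would expect compound 4 to give a higher number, with a step of a 4.3-fold higher number from compound 1 to compound 4 (0.64 log units; beyond the scatter). His estimate for compound 4 is 1500 nM, within a range of 500 nM to 5000 nM.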

Compound 4, half-maximal inhibitory concentration: < 51.3 nM
Compound 4 gave a limit, no number (the forecaster's own chance of this, stated with the estimate: 5%); middle value at least 29-fold (1.46 log units) away from the limit.
By their numbers in this assay, from the lowest: compound 1; then compound 3; then compound 2. At a limit, below all of these: compound 4.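

In this assay compound 4 sits at a limit of the assay rather than at a number: the limit of < 51.3 nM in this assay, at which 1 of the 4 values shown sits. Even so, the direction is clear, since isopropyl in place of phenyl on this aromatic carbon, next to the ring sulfur, gives an at least 6.7-fold lower number from compound 1 to compound 4 (0.83 log units; beyond the scatter). The earlier compounds shown here could not show this, as compound 1 alone carried a group at this place; its phenyl had seemed tied to its low number, but here a group with no ring and 3 heavy atoms instead of 6 does better, so the ring of the phenyl is not required at this position.

From the compounds shown here alone, how far below the limit compound 4 truly lies remains open. So does whether an ethyl, a tert-butyl or an amine at this place would keep the number as low as isopropyl does.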